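A few compounds are considered here, and "the series" means these few. Any claim that something is new, unique, unknown or untested is made for them only; others in the source may bear on it.

Measured compounds and their numbers in an assay on brain for binding affinity to adenosine receptor A1 (Rattus norvegicus), read by radioligand binding; on this read-out lower numbers stand for stronger inhibition and higher numbers for weaker inhibition:
- compound 1, `CCCn1c(=O)c2nc(-c3ccc(OCC(=O)NCCN=C(S)Nc4ccc(F)cc4)cc3)[nH]c2n(CCC)c1=O`: 15.5 nM
- compound 2, `CCCn1c(=O)c2nc(-c3ccc(OCC(=O)NCCNC(=O)CCCCC(C)=O)cc3)[nH]c2n(CCC)c1=O`: 44 nM
- compound 3, `CCCn1c(=O)c2nc(-c3ccc(OCC(=O)NCCNC(=O)CBr)cc3)[nH]c2n(CCC)c1=O`: 17.6 nM

All three share the core and the amide-linked chain; they differ only in the group at the end of that chain. Compound 3 stands second of the three numbers, with compound 1 within the scatter of it and compound 2 the furthest away, as the step of a 2.5-fold lower number from compound 2 to compound 3 (0.40 log units; beyond the scatter) shows. The step of a 1.1-fold higher number from compound 1 to compound 3 (0.06 log units; within the scatter) is within the scatter, so the large aryl-bearing group of compound 1 and the bromo of compound 3 give no distinguishable result.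

Compound 4, `CCCn1c(=O)c2nc(-c3ccc(OCC(=O)NCCNC(=O)CCCN4C(=O)C=CC4=O)cc3)[nH]c2n(CCC)c1=O`, carries the change (a group of 9 heavy atoms (6 carbon, 1 nitrogen, 2 oxygen; one five-membered non-aromatic ring with 1 hetero atom) in place of one bromine atom, on a saturated chain carbon bound to a carbonyl carbon). The step that bears most directly on it is a 2.5-fold lower number from compound 2 to compound 3 (0.40 log units; beyond the scatter), read in reverse: replacing bromo by a longer chain ending in a carbonyl-bearing group gave a modestly higher number. The step of a 2.8-fold higher number from compound 1 to compound 2 (0.45 log units; beyond the scatter) points the same way, a chain group giving a somewhat higher number than a ring-bearing group. Compound 4 adds a chain that ends in a ring, so the expected outcome lies between those cases: a modest rise in the number, a 1.7-fold higher number from compound 3 to compound 4 (0.23 log units; within the scatter), is expected. Compound 4 is therefore estimated at 30 nM, within 12 nM to 80 nM.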

Compound 4, inhibition constant: 37.8 nM
Compound 4: middle estimate off by 1.3-fold (0.10 log units), on the low side; the measured number falls inside the stated range.
By their numbers in this assay, from the lowest: compounds 1 and 3 (each within the scatter of the next); then compounds 4 and 2 (each within the scatter of the next).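

In this assay, placing the group with the five-membered non-aromatic ring on the saturated chain carbon bound to a carbonyl carbon, where bromo stood, gives a 2.1-fold higher number from compound 3 to compound 4 (0.33 log units; beyond the scatter), so this position responds to that exchange by a modest step beyond the scatter. The step of a 1.2-fold lower number from compound 2 to compound 4 (0.07 log units; within the scatter) lies within the scatter, so the ring-ending chain and the open chain ending in a carbonyl give no distinguishable result here, and the ring brings no separate gain or loss that these two compounds can show. No supporting data bear on why either step falls as it does.

Open, as far as these compounds go, is whether the rise from the bromo compound follows the ring or simply the added chain, a question that a longer chain ending in the same five-membered ring, or a plain alkyl chain in its place, would address. Also open is how this position takes an end group such as an amine or a carboxylic acid, since the end groups shown here carry no net charge.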